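Adding a Third Methoxy Group to a Chalcone-Type Compound

A few compounds are considered here, and "the series" means these few. Any claim that something is new, unique, unknown or untested is made for them only; others in the source may bear on it.

Measured compounds:
- Compound 1, `COc1ccc(C(=O)/C=C/c2cc(-c3cc(OC)c(OC)c(OC)c3)n[nH]2)cc1OC`: -41%
- Compound 2, `COc1cc(-c2cc(/C=C/C(=O)c3ccc(F)c(F)c3)[nH]n2)cc(OC)c1OC`: -36%

Both compounds were tested in a functional assay on RPMI-8226 cells (Homo sapiens) for cytotoxicity, read by sulforhodamine B assay, with a stated time of 48 h, tested at 100 uM; a higher number here means a weaker effect of the compound at the concentration tested, a lower number a stronger effect. Compound 1 gives -41% in this assay. Compound 2 gives -36%, and the step of a number 5 percentage points higher from compound 1 to compound 2 (within the scatter) shows that the two values cannot be told apart; compound 1 stands among numbers that are indistinguishable from its own.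

Compound 3, `COc1cc(C(=O)/C=C/c2cc(-c3cc(OC)c(OC)c(OC)c3)n[nH]2)cc(OC)c1OC`, has not yet been measured. It differs from compound 1 in one place: methoxy in place of hydrogen on an aromatic carbon. Going by the values given here, this change alters the same aromatic group on the carbonyl carbon that was altered in the one measured step, where a 3,4-difluorophenyl replaced a 3,4-dimethoxyphenyl and the result stayed within the scatter. Among the compounds with values here, no measured step speaks directly to adding a methoxy group, so the expectation rests on that single comparison.

Compound 3 is therefore expected to give a number close to that of compound 1, with the expected step of a number 1 percentage points higher from compound 1 to compound 3 (within the scatter) not exceeding the scatter. The estimate for compound 3 in this assay is -40%, between -62% and -18%.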

Compound 3, a percentage reported as activity, at one concentration (the size of the read-out at that concentration, not a potency): -26%
Compound 3: middle estimate off by 14 percentage points, on the low side; the measured number falls inside the stated range.
By their numbers in this assay, from the lowest: compounds 1, 2 and 3 (each within the scatter of the next, the first and the last beyond it).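

Placing methoxy in place of hydrogen on this aromatic carbon, ortho to a methoxy group and meta to a large group, gives a number 15 percentage points higher from compound 1 to compound 3 (beyond the scatter) in this assay, so the effect at the tested concentration is modestly weaker. Going by these compounds alone, the earlier change to the same aromatic group on the carbonyl carbon, a number 5 percentage points higher from compound 1 to compound 2 (within the scatter), could not be told apart from repeat-measurement noise, so this is the first readable sign that the group is not indifferent to substitution, and a single added methoxy is enough to produce it. No measurement at hand accounts for the shift.

The compounds shown cannot tell whether the weaker effect belongs to methoxy itself or would come with any group at this position, and a small atom such as fluorine, a hydroxyl or an amine there would help separate those two readings. A longer chain such as ethoxy in the same place would show whether the number keeps rising as the group grows or stays near that of compound 3.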